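The source may hold more compounds than are shown below. What is called first, only, known or untested is meant among the compounds shown, and "the series" means these compounds.

Measured in a functional assay on A-375 cells (Homo sapiens) for antiproliferative activity; on this read-out higher numbers stand for weaker inhibition and lower numbers for stronger inhibition:
- Compound 1 `O=C(Nc1ccc(-c2cscn2)cc1)C1CCN(Cc2ccc(F)c(F)c2)C1`: 10000 nM
- Compound 2 `O=C(NC1CCCN(Cc2ccc(F)c(F)c2)C1)c1ccc(-c2cscn2)cc1`: > 20000 nM
- Compound 3 `O=C(Nc1ccc(-c2cscn2)cc1)C1CCCN(Cc2ccc(F)cc2)C1`: 2250 nM

Only two of these entries are actual numbers. Compound 2 has only a limit, > 20000 nM. Compound 3, at 2250 nM, has the lower of the two numbers. Compound 1 sits higher at 10000 nM, a gap beyond the usual scatter, so compound 3 is the better inhibitor of this pair.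

Compound 4 `O=C(Nc1ccc(-c2cscn2)cc1)C1CCCN(Cc2cccc(C(F)(F)F)c2)C1` has not yet been measured. It keeps the rest of compound 3 but carries 3-(trifluoromethyl)phenyl in place of 4-fluorophenyl on a saturated chain carbon bound to an amine nitrogen in a ring. The swap leaves one six-membered aromatic ring of carbon only at this place, with no hydrogen-bond donors or acceptors and no net charge.

Among the measured compounds shown here, no two measured compounds differ in just one place, so the data give no direct guide to the size of this step. For the measured compounds named here, with no measured step to point either way, the expectation in this assay is no change beyond the scatter, and the estimate stays close to compound 3 at 2250 nM. The expected change is a 1.1-fold higher number from compound 3 to compound 4 (0.05 log units; within the scatter). The estimated value for compound 4 is 2500 nM, with an expected range from 800 nM to 8000 nM.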

Compound 4, half-maximal inhibitory concentration: > 20000 nM
Compound 4 was reported as a limit; the forecaster's own chance of this, stated with the estimate: 10%; at least 8.0-fold (0.90 log units) between middle value and limit.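

In this assay compound 4 is reported only as a limit, > 20000 nM, and not as a number. Even so, it supplies the first step in this set that changes a single place, the saturated chain carbon bound to an amine nitrogen in a ring: putting 3-(trifluoromethyl)phenyl in place of 4-fluorophenyl gives an at least 8.8-fold higher number from compound 3 to compound 4 (0.94 log units; beyond the scatter), so what sits at this place clearly matters for inhibition, even though the aromatic ring itself stays and no hydrogen-bond donors, hydrogen-bond acceptors or net charge are added. From the compounds shown here alone, the real size of the step remains unknown, and the figure is only a lower bound, because the reading for compound 4 stops at a limit of the assay: the limit of > 20000 nM in this assay, at which 2 of the 4 values shown sit.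

This single swap changes the substituent on the aromatic ring and its location together, so the compounds shown cannot tell whether the weaker inhibition follows from the trifluoromethyl group itself or from where it sits. They also leave open how a plain phenyl ring, or a phenyl ring carrying a methoxy group, would behave at this place, and so whether the fluorine of compound 3 contributes anything to its inhibition.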